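Weak Anoctamin-2 Inhibitors: From an Ester Side Chain to Trifluoromethyl

This account rests on a few compounds, and the source may have more. Where it says the series, first, only, none or still open, it means among the compounds named here.

Measured so far:
compound 1, `Cc1cc(Cl)ccc1OCc1nnc(-c2ccccc2C(F)(F)F)o1`, > 100000 nM (a limit)
compound 2, `COc1cccc(-c2nnc(COc3ccc(Cl)cc3C)o2)c1`, > 100000 nM (a limit)
compound 3, `CCOC(=O)C(F)Oc1ccccc1/C=N/NC(=O)COc1ccc(Cl)cc1C`, 59400 nM

All three were tested in an ADME assay on cells for inhibition of anoctamin-2 (Homo sapiens), read by fluorescence, with a stated time of 20 min; a lower number here means a stronger inhibitor, a higher number a weaker inhibitor. Compound 1 gives no number there, only the limit > 100000 nM. Compound 2 likewise reaches only the limit > 100000 nM. Among the compounds with values here, compound 3 is the sole compound with a measured value, 59400 nM, and so it stands alone at the weak end of what can be read, while the other two sit at the limit of > 100000 nM in this assay, at which 2 of the 3 values shown sit. Compound 4 `Cc1cc(Cl)ccc1OCC(=O)N/N=C/c1ccccc1C(F)(F)F` is not yet measured. It differs from compound 3 by trifluoromethyl in place of (ethoxycarbonyl)(fluoro)methoxy on an aromatic carbon. Within the data shown here, no measured pair shows this exact change, so its size cannot be read from the data. Compound 1 also carries a trifluoromethyl group, but on a different core, so it gives no direct guide. The step from compound 3 to compound 4 in this assay is expected to be a 1.5-fold higher number from compound 3 to compound 4 (0.18 log units; within the scatter), small and toward weaker inhibition, hardly beyond the scatter. Compound 4 is therefore expected to give about 90000 nM, with a range from 30000 nM to 300000 nM, and a fair chance of only a limit.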

Compound 4, half-maximal inhibitory concentration: "not active" (no number reported)
Compound 4 has no reported number here; the estimate stays without a comparison.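

Within the data shown here, compound 4 is reported only as "not active", without a number, while compound 3 gives 59400 nM, so no step between compound 3 and compound 4 can be read. The compounds shown leave open whether trifluoromethyl in place of (ethoxycarbonyl)(fluoro)methoxy shifts inhibition at all, and how far.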